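A few compounds are considered here, and "the series" means these few. Any claim that something is new, unique, unknown or untested is made for them only; others in the source may bear on it.

Measured so far:
compound 1, `CC(=O)c1ccc(OCCCN2CCN(c3ncccn3)CC2)cc1`: > 100 nM
compound 2, `CC(C)(C)c1ccc(OCCCN2CCN(c3ncccn3)CC2)cc1`: 40.4 nM
compound 3, `CC(=O)c1ccc(OCCCCN2CCN(c3ncccn3)CC2)cc1`: > 100 nM

In a functional assay on L5178Y cells (Mus musculus) for cytotoxicity, read by MTT assay (a higher number here means a weaker inhibitor, a lower number a stronger inhibitor), compound 1 gives only a limit, > 100 nM. Compound 3 also gives only a limit, > 100 nM, and this is the limit of > 100 nM in this assay, at which 2 of the 3 values shown sit. Compound 2 gives 40.4 nM in this assay, so there is an at least 2.4-fold lower number from compound 1 to compound 2 (0.39 log units; beyond the scatter). The change behind that step is tert-butyl in place of acetyl on an aromatic carbon.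

Compound 4, `CC(C)(C)c1ccc(OCCCCN2CCN(c3ncccn3)CC2)cc1`, is not yet measured. It differs from compound 3 by tert-butyl in place of acetyl on an aromatic carbon, the same change as from compound 1 to compound 2, since the place of the change is described in the same words for both pairs. How the core of compound 3 differs from the core of compound 1 is not broken down here.

In this assay the step expected is an at least 2.2-fold lower number from compound 3 to compound 4 (0.34 log units; beyond the scatter), resting on compound 1 and compound 2 showing an at least 2.4-fold lower number from compound 1 to compound 2 (0.39 log units; beyond the scatter) from the same change, and on compound 3 standing at the limit of > 100 nM in this assay, at which 2 of the 3 values shown sit. Compound 4 is estimated at 45 nM, between 20 nM and 100 nM.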

Compound 4, half-maximal inhibitory concentration: 20.8 nM
Compound 4: middle estimate off by 2.2-fold (0.34 log units), on the high side, and the stated range covers the measured number.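

In this assay, going by these compounds, tert-butyl in place of acetyl on an aromatic carbon gives an at least 4.8-fold lower number from compound 3 to compound 4 (0.68 log units; beyond the scatter), so the change carries over in direction from the core of compound 1 to the core of compound 3, and set side by side the two steps read: the same change on two cores in this assay, an at least 2.4-fold lower number (0.39 log units; beyond the scatter) from compound 1 to compound 2 and an at least 4.8-fold lower number (0.68 log units; beyond the scatter) from compound 3 to compound 4; the limit leaves it open whether they differ Compound 3 gives only a limit, > 100 nM, and the true size of its step therefore stays unknown. The result thus shows that the direction of the change held on both cores shown, but it does not show that the change is worth more on one core than on the other, and two cores do not make a rule for the series.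

The compounds shown carry only acetyl or tert-butyl at this place, which leaves open how an amine or a carboxylic acid there would read in this assay. They also leave open whether the change would hold on a core with a longer chain.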